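Removing a Hydroxyl from an Inactive Compound

The source may report more compounds than this note shows. Statements on the series, on what has been measured and on what is new or still open speak of the compounds shown alone.

Compounds measured in a functional assay on HL-60 cells (Homo sapiens) for inhibition, read by MTT assay, with a stated time of 72 h; on this read-out lower numbers stand for stronger inhibition and higher numbers for weaker inhibition:
Compound 1 `Cc1nc(-c2ccc(F)cc2)c(C(=O)N2CCN(c3cccc(Cl)c3)CC2)o1`: 40.1 nM
Compound 2 `COc1ccc(-c2nc(C)oc2C(=O)N2CCN(c3cccc(Cl)c3)CC2)cc1`: "not active" (no number reported)
Compound 3 `COc1ccc(-c2nc(C)oc2C(=O)N2CCN(c3cccc(Cl)c3)CC2)cc1O`: "not active" (no number reported)

Compound 3 cannot be placed on the numerical scale, since this assay gives no single number for it. Compound 2 also has no number, so compound 1 provides the only figure in this small set.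

The next structure is compound 4 `COc1cccc(-c2nc(C)oc2C(=O)N2CCN(c3cccc(Cl)c3)CC2)c1`, which has not yet been measured. The structural change is 3-methoxyphenyl in place of 3-hydroxy-4-methoxyphenyl on an aromatic carbon: 3-methoxyphenyl replaces 3-hydroxy-4-methoxyphenyl on an aromatic carbon of a five-membered aromatic ring with 1 nitrogen and 1 oxygen. The rest of the molecule stays the same.

Compound 1 gives 40.1 nM with a different group at this place, which shows that the shared core can yield a number in this assay. Compounds 2 and 3 show that it does not always do so. A step towards stronger inhibition is expected, though its size cannot be stated without a number for compound 3. Compound 4 may well also return no number, and the range is wide for that reason. If a number is reported, the expected value for compound 4 is 300 nM, with an estimated range of 30 nM to 3000 nM.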

Compound 4, half-maximal inhibitory concentration: "not active" (no number reported)
No number was reported for compound 4; there is nothing to compare the estimate with.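

In this assay compound 3 and compound 4 are both reported as not active, without a number, so no step can be read between them. The compounds shown leave open whether 3-methoxyphenyl and 3-hydroxy-4-methoxyphenyl differ at all in strength of inhibition. No measurement shown here offers an explanation for this result.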